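Diol ether replacing the carboxy chain in compound 3

A few compounds are considered here, and "the series" means these few. Any claim that something is new, unique, unknown or untested is made for them only; others in the source may bear on it.

compound 1 `COc1cc(C2CN(C(=O)c3cc(OC[C@@H](O)CO)ccn3)C2)ccc1OCc1ccc(C2CC2)cc1`: 68%
compound 2 `COc1cc(C2CN(C(=O)c3cc(OCCCC(=O)O)ccn3)C2)ccc1OCc1ccc(C2CC2)cc1`: 88%
compound 3 `COc1cc(C2CN(C(=O)c3cc(OCCCC(C)(C)C(=O)O)ccn3)C2)ccc1OCc1ccc(C2CC2)cc1`: 76%

In an ADME assay on S9 fraction from liver (Mus musculus, strain CD-1) for metabolic stability, read by LC-MS, using NADPH, with stated times of 5 min and 60 min, tested at 5 uM (on this read-out lower numbers stand for a less stable compound and higher numbers for a more stable compound), compound 3 gives 76%, within the scatter of compound 1. Against the highest value of the three there is a number 12 percentage points lower from compound 2 to compound 3 (beyond the scatter).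

The next structure is compound 4 `COc1cc(C2CN(C(=O)c3cc(COC[C@H](O)CO)ccn3)C2)ccc1OCc1ccc(C2CC2)cc1`, with (2,3-dihydroxypropoxy)methyl in place of (4-carboxy-4-methylpentyl)oxy on an aromatic carbon, opposite the ring nitrogen ((2,3-dihydroxypropoxy)methyl in place of (4-carboxy-4-methylpentyl)oxy on an aromatic carbon). For the measured compounds named here, no measured compound carries this group itself. The nearest evidence starts from the one measured dihydroxy chain: a number 8 percentage points higher from compound 1 to compound 3 (within the scatter), and a number 20 percentage points higher from compound 1 to compound 2 (beyond the scatter). Both run from that chain to a carboxy chain, so the reverse direction is expected here, a modest drop in this assay close to the edge of the scatter. The expected step is a number 10 percentage points lower from compound 3 to compound 4 (within the scatter). The estimated value for compound 4 is 66%, with an expected range of 52% to 80%.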

Compound 4, percent of the compound remaining: 70%
Compound 4: middle estimate off by 4 percentage points, on the low side; low and high end bracket the measured number.
By their numbers in this assay, from the lowest: compounds 1, 4 and 3 (each within the scatter of the next); then compound 2.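

In this assay, (2,3-dihydroxypropoxy)methyl in place of 2,3-dihydroxypropoxy stays within the scatter at this position opposite the ring nitrogen (a number 2 percentage points higher from compound 1 to compound 4 (within the scatter)), so this change of the linking atoms gives no readable shift. The same holds against (4-carboxy-4-methylpentyl)oxy (a number 6 percentage points lower from compound 3 to compound 4 (within the scatter)), whereas against 3-carboxypropoxy the gap lies beyond the scatter (a number 18 percentage points lower from compound 2 to compound 4 (beyond the scatter)). No available measurement bears on a cause for these steps.

Still open, as far as these compounds go, is how an amine on this aromatic carbon would compare with the diol chains. Also open, from the compounds shown here alone, is whether a carboxylic acid on a chain with the same methylene-ether link would match compound 2.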